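Resorcinol isoxazole series: pyrrolidinylmethyl replacement for carboxymethoxymethyl

The compounds below may be only part of what the source reports. "The series", "measured", "known", "first", "only" and "open" are said of these compounds alone.

Measured so far:
compound 1, `CCNC(=O)c1noc(-c2cc(C(C)C)c(O)cc2O)c1-c1cc(CO)no1`, 5 nM
compound 2, `CCNC(=O)c1noc(-c2cc(C(C)C)c(O)cc2O)c1-c1cc(COCC(=O)O)no1`, "not determined" (no result reported)

Going by the values given here, compound 1 is the only member of the series with a number in a functional assay on A2780 cells (Homo sapiens) for inhibition; a higher number here means a weaker inhibitor, a lower number a stronger inhibitor; compound 1 gives 5 nM. Compound 2 was tested in this assay but no result was reported, so compound 2 stands nowhere on the numbers shown and no step from compound 1 to compound 2 can be read off.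

Compound 3, `CCNC(=O)c1noc(-c2cc(C(C)C)c(O)cc2O)c1-c1cc(CN2CCCC2)no1`, is the next compound to be measured in this assay. It differs from compound 2 in one place: pyrrolidin-1-yl in place of carboxymethoxy on a saturated chain carbon bound to an aromatic carbon. Among the compounds with values here, since compound 2 carries no value, the size and direction of the step to compound 3 in this assay cannot be taken from the data; the expectation is that the change is not more than the usual scatter, with no direction implied beyond it, and the only anchor is compound 1 at 5 nM.

For compound 3 the estimate in this assay is 10 nM, expected to fall between 3 nM and 40 nM.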

Compound 3, half-maximal inhibitory concentration: 55 nM
The estimate for compound 3 lay 5.5-fold (0.74 log units) below the measured number; measured number above the stated range.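

In this assay, going by these compounds alone, pyrrolidin-1-yl in place of hydroxy on a saturated chain carbon bound to an aromatic carbon gives an 11-fold higher number from compound 1 to compound 3 (1.04 log units; beyond the scatter) on an otherwise unchanged structure, the first readable step at this position. This position is therefore not indifferent to the group it carries, although compound 3, at 55 nM, still gives a numerical result in this assay, and the step from compound 2 to compound 3 cannot be read, as compound 2 has no reported value. No supporting data accompany these results to account for the higher number of compound 3.

On these data alone, it remains open whether the step follows the ring of pyrrolidin-1-yl or its amine nitrogen, a question that an open-chain dimethylamino group or a morpholin-4-yl ring on the same saturated chain carbon would help to separate. As far as these compounds go, it also remains open where carboxymethoxy stands relative to hydroxy and pyrrolidin-1-yl at this position, so the two-compound comparison gives no trend across the wider set of groups.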